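Swapping the amide aryl group for propyl on a fluorophenyl core

The compounds below may be only part of what the source reports. "The series", "measured", "known", "first", "only" and "open" are said of these compounds alone.

Measured so far in a functional assay on QGY7701 cells (Homo sapiens) for cytotoxicity, read by MTT assay, with a stated time of 24 h; on this read-out lower numbers stand for stronger inhibition and higher numbers for weaker inhibition:
- compound 1, `C=CC1=C(C(=O)Nc2ccccc2)C(c2ccc(Cl)c(Cl)c2)OC1`, a limit of > 100000 nM
- compound 2, `C=CC1=C(C(=O)Nc2cccc(C)c2)C(c2ccc(F)cc2)OC1`, 56400 nM
- compound 3, `C=CC1=C(C(=O)NCCC)C(c2ccc(Cl)c(Cl)c2)OC1`, 31300 nM

Compound 1 reaches only the assay limit in this assay, so no number is known for it (the limit of > 100000 nM in this assay, at which 1 of the 3 values shown sits). Of the two numbers that are known, compound 2 gives the higher one, but its gap to compound 3 is within the usual scatter, so the two cannot be ranked.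

Compound 4, `C=CC1=C(C(=O)NCCC)C(c2ccc(F)cc2)OC1`, has not been measured. It differs from compound 2 in one place: propyl in place of 3-methylphenyl on an amide-type nitrogen. The closest measured comparison is the step of an at least 3.1-fold lower number from compound 1 to compound 3 (0.50 log units; beyond the scatter), where propyl replaces phenyl on the same amide nitrogen in the dichlorophenyl series. That step gave a clearly lower number, so a lower number is expected for compound 4 as well, though the size is uncertain since compound 1 only reached a limit.

Compound 4 is therefore expected to give 20000 nM in this assay, within a range of 8000 nM to 50000 nM, which corresponds to an estimated step of a 2.8-fold lower number from compound 2 to compound 4 (0.45 log units; beyond the scatter).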

Compound 4, half-maximal inhibitory concentration: > 100000 nM
Compound 4: a limit, no number; the forecaster's own chance of this, stated with the estimate: 5%; middle value at least 5.0-fold (0.69 log units) away from the limit.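

In this assay, propyl in place of 3-methylphenyl on the amide-type nitrogen gives an at least 1.7-fold higher number from compound 2 to compound 4 (0.24 log units; that floor lies within the scatter), so the lower number seen with propyl in the dichlorophenyl pair, an at least 3.1-fold lower number from compound 1 to compound 3 (0.50 log units; beyond the scatter), is not repeated on the fluorophenyl core. Only a floor is known for the new step and it lies within the scatter, so a real rise is not established, but the two swaps clearly do not behave alike. Compound 4 is a limit of the assay, not a number, and it shares that limit with one other compound: the limit of > 100000 nM in this assay, at which 2 of the 4 values shown sit.

The two pairs differ both in the aryl group that leaves and in the halogens on the other phenyl ring, and the compounds shown cannot separate these two differences. Going by these compounds, whether a longer chain such as butyl, or a chain ending in an amine, would give a measurable number on the fluorophenyl core remains open.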